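The source may hold more compounds than are shown below. What is called first, only, known or untested is meant among the compounds shown, and "the series" means these compounds.

Values measured in a functional assay on A549 cells (Homo sapiens) for cytotoxicity; on this read-out lower numbers stand for stronger inhibition and higher numbers for weaker inhibition:

- compound 1 `C=C/C=C\[C@H](C)[C@H](OC(N)=O)[C@@H](C)[C@H](O)[C@@H](C)C/C(C)=C\[C@H](C)[C@@H](O)[C@@H](C)/C=C\[C@@H](O)C[C@@H]1OC(=O)C(C)=C[C@H]1C`: 21.7 nM
- compound 2 `CCCC[C@H](C)[C@H](OC(N)=O)[C@@H](C)[C@H](O)[C@@H](C)C/C(C)=C\[C@H](C)[C@@H](O)[C@@H](C)/C=C\[C@@H](O)C[C@@H]1OC(=O)[C@H](C)[C@@H](O)[C@H]1C`: 8.4 nM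
- compound 3 `C=C/C=C\[C@H](C)[C@H](OC(N)=O)[C@@H](C)[C@H](OC(C)=O)[C@@H](C)C/C(C)=C\[C@H](C)[C@@H](OC(C)=O)[C@@H](C)/C=C\[C@H](C[C@@H]1OC(=O)C(C)=C[C@H]1C)OC(C)=O`: > 7130 nM, a limit and not a number

Of the two exact numbers, compound 1 has the higher one, and compound 2 lies below it by more than the scatter. Compound 4 `C=C/C=C\[C@H](C)[C@H](OC(N)=O)[C@@H](C)[C@H](O)[C@@H](C)C/C(C)=C\[C@H](C)[C@@H](OC(C)=O)[C@@H](C)/C=C\[C@@H](O)C[C@@H]1OC(=O)C(C)=C[C@H]1C` is compound 1 with one change: acetyl in place of hydrogen on an oxygen on a saturated carbon, or hydroxy to acetoxy. Among the compounds with values here, no measured pair shows this change alone. With acetoxy in place of every hydroxy of the core, compound 3 reads > 7130 nM, which is a limit. Within the data shown here, only one such change is made here, so in this assay a higher number is expected, an estimated step of a 5.5-fold higher number from compound 1 to compound 4 (0.74 log units; beyond the scatter) that goes beyond the scatter. For compound 4 the estimated value is 120 nM, with an expected range of 25 nM to 700 nM.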

Compound 4, half-maximal inhibitory concentration: 3130 nM
The estimate for compound 4 lay 26-fold (1.42 log units) below the measured number, and the stated range ends below it.
By their numbers in this assay, from the lowest: compound 2; then compound 1; then compound 4. At a limit, above all of these: compound 3.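

In this assay, acetyl in place of hydrogen on this one oxygen alone gives a 140-fold higher number from compound 1 to compound 4 (2.16 log units; beyond the scatter), so a single hydroxy to acetoxy change is enough for a large loss of potency. Compound 3 had shown only the result of changing every hydroxy of the core at once. Its value is a limit and not a number, so what the other acetoxy groups add cannot be read: the limit of > 7130 nM in this assay, at which 1 of the 4 values shown sits.

On these data alone, whether the loss comes from losing the hydroxy or from the size of the acetyl stays open, and a methoxy or a longer ester such as butyryl on this oxygen could separate the two. As far as these compounds go, how each other hydroxy behaves when acetylated alone also stays open.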